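The compounds below may be only part of what the source reports. "The series", "measured", "known", "first", "only" and "open" are said of these compounds alone.

Measured so far:
- compound 1, `CCNC(=O)CC1CCc2cc(OC)c(OC)cc21`: 26%
- compound 2, `CCN(CC)C(=O)CC1CCc2cc(OC)c(OC)cc21`: 40%
- compound 3, `CCCNC(=O)CC1CCc2cc(OC)c(OC)cc21`: 28%

These three share one core and differ only in the group on the amide nitrogen. In a functional assay on the whole organism (strain Wistar) for inhibition, with Rattus norvegicus as the target, read by paw edema, with stated times of 60 min and 2 h, at a dose of 100 mg/kg by the oral route (on this read-out higher numbers stand for more inhibition at the one dose given (going by the name of the read-out) and lower numbers for less inhibition), compound 3 gives 28% and stands second of the three: its gap to compound 1 lies within the scatter, while compound 2 sits above it, as a number 12 percentage points lower from compound 2 to compound 3 (beyond the scatter) shows in reverse.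

Compound 4, `COc1cc2c(cc1OC)C(CC(=O)NC(C)(C)C)CC2`, carries tert-butyl in place of propyl on an amide-type nitrogen. Within the data shown here, two measured steps bear on this. Lengthening the nitrogen substituent by one carbon, a number 2 percentage points higher from compound 1 to compound 3 (within the scatter), changed nothing beyond the scatter. Adding a second alkyl group to the nitrogen, a number 14 percentage points higher from compound 1 to compound 2 (beyond the scatter), raised the read-out modestly. Among the measured compounds shown here, the change to compound 4 adds one carbon but keeps a single substituent on the nitrogen, and no measured step tests branching, so a step of a number 4 percentage points higher from compound 3 to compound 4 (within the scatter) is expected, not beyond the scatter. Compound 4 is therefore estimated at 32%, within 18% to 46%.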

Compound 4, a percentage reported as inhibition, in the whole organism at one dose (the size of the read-out at that dose, not a potency): 32%
The estimate for compound 4 equals the measured number at the digits printed; measured number inside the range.
By their numbers in this assay, from the lowest: compounds 1, 3, 4 and 2 (each within the scatter of the next, the first and the last beyond it).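

Swapping the straight propyl for tert-butyl on the amide-type nitrogen is the first branched group at this position, and in this assay it gives a number 4 percentage points higher from compound 3 to compound 4 (within the scatter); set against ethyl, tert-butyl gives a number 6 percentage points higher from compound 1 to compound 4 (within the scatter), so among these three amides with a single nitrogen substituent, neither chain length nor this branching separates the numbers. The comparison with the diethyl amide gives a number 8 percentage points lower from compound 2 to compound 4 (within the scatter), so the tert-butyl amide cannot be told apart from it either, even though the diethyl amide stands clear of the ethyl and propyl amides. No measurement here explains why these groups read as they do.

Still open, as far as these compounds go, is whether a chain ending in an amine or a carboxylic acid on this nitrogen would move the read-out further. Also open, from the compounds shown here alone, is whether two propyl groups there would read like the two ethyl groups.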